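Swapping the methoxyphenyl arm for a dichlorophenyl one

A few compounds are considered here, and "the series" means these few. Any claim that something is new, unique, unknown or untested is made for them only; others in the source may bear on it.

Compound 1 `COc1ccc(-c2nc(SCC(=O)c3sc(-c4ccccc4)nc3C)[nH]c(=O)c2C#N)cc1`: 97.3%
Compound 2 `COc1ccc(-c2nc(C)c(C(=O)CSc3nc(-c4ccc(OC)cc4)c(C#N)c(=O)[nH]3)s2)cc1`: 97%
Compound 3 `COc1ccc(-c2nc(C)c(C(=O)CSc3nc(-c4ccc(OC)c(OC)c4)c(C#N)c(=O)[nH]3)s2)cc1`: 81.2%

Of the compounds shown here, three have been measured in a functional assay on U-87MG ATCC cells for antiproliferative activity against U-87 MG (Homo sapiens), read by MTT assay, with a stated time of 48 h, tested at 5 uM; a higher number here means a weaker effect of the compound at the concentration tested, a lower number a stronger effect. Compound 1 gives 97.3% there, the highest of the three numbers; compound 2, with its 97%, sits within the scatter of compound 1, while compound 3, at 81.2%, lies beyond it. The two measured steps were a number 0.3 percentage points lower from compound 1 to compound 2 (within the scatter) and a number 15.8 percentage points lower from compound 2 to compound 3 (beyond the scatter).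

Compound 4 `Cc1nc(-c2ccccc2)sc1C(=O)CSc1nc(-c2ccc(Cl)c(Cl)c2)c(C#N)c(=O)[nH]1` has not yet been measured. It differs from compound 1 in one place: 3,4-dichlorophenyl in place of 4-methoxyphenyl on an aromatic carbon. Neither of the measured steps involves this exchange; both add a methoxy group to an aromatic carbon rather than replacing one aryl group by another, so they bear on the new step only loosely. The step from compound 2 to compound 3 shows that a change on a six-membered aromatic ring of carbon only can shift the read-out modestly; the step from compound 1 to compound 2 shows it can also leave it unmoved. An account of compound 4 therefore expects a step of a number 9.3 percentage points lower from compound 1 to compound 4 (within the scatter), a modest lowering at most. The estimated value for compound 4 is 88%, within 70% to 100%.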

Compound 4, a percentage reported as activity, at one concentration (the size of the read-out at that concentration, not a potency): 98.6%
Beside the measured number, compound 4's estimate is 10.6 percentage points below it; the range from low to high includes it.
By their numbers in this assay, from the lowest: compound 3; then compounds 2, 1 and 4 (each within the scatter of the next).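

In this assay, the exchange of 4-methoxyphenyl for 3,4-dichlorophenyl on the aromatic carbon ortho to a cyano group gives a number 1.3 percentage points higher from compound 1 to compound 4 (within the scatter), so the first replacement of this whole arm leaves the read-out where it was. The arm that enters has the same count of heavy atoms but carries two chlorine atoms and no hydrogen-bond acceptor, and at this concentration that exchange cannot be told apart from the usual scatter, whereas a further methoxy on the same arm gave a number 15.8 percentage points lower from compound 2 to compound 3 (beyond the scatter). No measurement shown here accounts for either outcome.

From the compounds shown here alone, what remains open is whether this position tolerates other kinds of group, such as an amine or a carboxylic acid on the phenyl ring, or whether those would move the read-out as the added methoxy did. Going by these compounds, it is also open whether 3,4-dichlorophenyl would behave the same way on the core of compound 2, which carries a methoxy on its other phenyl ring, and whether a step would appear at a higher concentration.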